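A few compounds are considered here, and "the series" means these few. Any claim that something is new, unique, unknown or untested is made for them only; others in the source may bear on it.

Compound 1 `C=CCOc1ccc(C(=O)/C=C/c2cc(OC)ccc2OC)cc1` gives 55000 nM
Compound 2 `COc1ccc(OC)c(/C=C/C(=O)c2ccc(O)cc2)c1` gives 22000 nM
Compound 3 `COc1cc(OC)c(OC)cc1/C=C/C(=O)c1ccc(O)cc1` is not yet measured

In a functional assay (Homo sapiens) for inhibition (on this read-out higher numbers stand for weaker inhibition and lower numbers for stronger inhibition), compound 2 stands lowest of the two numbers (22000 nM). Compound 3 carries methoxy in place of hydrogen on an aromatic carbon, ortho to a methoxy group, meta to a methoxy group and para to a large group (methoxy in place of hydrogen on an aromatic carbon). For the measured compounds named here, the only measured step (a 2.5-fold lower number from compound 1 to compound 2 (0.40 log units; beyond the scatter)) was modest and lies at a different place, so it bears only loosely and gives no direction. The expected change is small, within the scatter (a 1.2-fold lower number from compound 2 to compound 3 (0.09 log units; within the scatter)). For compound 3 the estimated value is 18000 nM, with an expected range from 6000 nM to 55000 nM.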

Compound 3, half-maximal inhibitory concentration: 28000 nM
For compound 3 the middle estimate is 1.6-fold (0.19 log units) below the measured one; the range from low to high includes it.
By their numbers in this assay, from the lowest: compounds 2, 3 and 1 (each within the scatter of the next, the first and the last beyond it).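

In this assay, methoxy in place of hydrogen on this aromatic carbon, ortho to a methoxy group, meta to a methoxy group and para to a large group, gives a 1.3-fold higher number from compound 2 to compound 3 (0.10 log units; within the scatter). For the compounds shown here, the only earlier step concerned a different place, whereas this one shows that adding methoxy here leaves the number within the scatter. Nothing measured here offers an explanation for this result.

From the compounds shown here alone, whether an amine, a carboxylic acid or a longer chain on this same carbon would shift the number remains open. So does whether methoxy here would give the same result with allyl on the oxygen, as in compound 1.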